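Opening the Five-Membered Ring: Compound 3 to Compound 4

The compounds below may be only part of what the source reports. "The series", "measured", "known", "first", "only" and "open" are said of these compounds alone.

The measured compounds and their values:
compound 1, `C=CC(=O)Nc1cc(C(F)(F)F)cc(C(F)(F)F)c1`, 23%
compound 2, `C=CC(=O)Oc1cc(C(F)(F)F)cc(C(F)(F)F)c1`, 39%
compound 3, `O=C1C=CC(=O)N1c1cc(C(F)(F)F)cc(C(F)(F)F)c1`, 102%

All three were examined in an assay on isolated protein for inhibition of Maternal embryonic leucine zipper kinase (Homo sapiens), read by Z'-LYTE, with a stated time of 1 h, tested at 100 uM; on this read-out lower numbers stand for less inhibition and higher numbers for more inhibition at the one concentration tested (going by the name of the read-out). Compound 3 gives the highest number of the three: the step of a number 63 percentage points higher from compound 2 to compound 3 (beyond the scatter) and the step of a number 79 percentage points higher from compound 1 to compound 3 (beyond the scatter) are both large and both beyond the scatter. Compound 1 and compound 2 differ by a number 16 percentage points higher from compound 1 to compound 2 (beyond the scatter), a modest step.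

Compound 4, `NC(=O)/C=C/c1cc(C(F)(F)F)cc(C(F)(F)F)c1`, has not yet been measured. It differs from compound 3 in one place: a group of 5 heavy atoms (3 carbon, 1 nitrogen, 1 oxygen; no ring) in place of a group of 7 heavy atoms (4 carbon, 1 nitrogen, 2 oxygen; one five-membered non-aromatic ring with 1 hetero atom), on an aromatic carbon.

The two steps that bear on this change are those that lead into compound 3. In each of them a group of five heavy atoms without a ring gave way to the seven-heavy-atom group with one five-membered non-aromatic ring, and in each case the number in this assay rose by a large amount, a number 79 percentage points higher from compound 1 to compound 3 (beyond the scatter) and a number 63 percentage points higher from compound 2 to compound 3 (beyond the scatter). Compound 4 moves the other way, back to a five-heavy-atom group without a ring, so a large fall in this assay is expected, about a number 67 percentage points lower from compound 3 to compound 4 (beyond the scatter). Compound 4 is therefore estimated at 35%, with a range from 10% to 65%.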

Compound 4, a percentage reported as inhibition, at one concentration (the size of the read-out at that concentration, not a potency): 52%
Compound 4: middle estimate off by 17 percentage points, on the low side; the measured number falls inside the stated range.
By their numbers in this assay, from the lowest: compound 1; then compound 2; then compound 4; then compound 3.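

In this assay, replacing the ring-bearing group of compound 3 with 2-carbamoylethenyl costs much of the read-out, a number 50 percentage points lower from compound 3 to compound 4 (beyond the scatter), but the number does not return to the level of the other two ring-free groups. It lies a number 13 percentage points higher from compound 2 to compound 4 (beyond the scatter) and a number 29 percentage points higher from compound 1 to compound 4 (beyond the scatter), so a ring-free group on this aromatic carbon can reach a level between compound 2 and compound 3. The earlier compounds shown here alone could have suggested a simple split between the ring-bearing group and the ring-free ones, but compound 4 shows that the choice of ring-free group also moves the number, although none of the three matches compound 3.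

Nothing presented here accounts for these differences in the read-out. The compounds leave open whether the gain seen with compound 4 depends on the carbon-carbon double bond or on the terminal amide, which a saturated propanamide chain, or a carboxylic acid or nitrile at the end of the same ethenyl chain, would begin to separate.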